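The source may hold more compounds than are shown below. What is called first, only, known or untested is meant among the compounds shown, and "the series" means these compounds.

Three compounds have been measured in a functional assay on PANC-1 cells (Homo sapiens) for inhibition, read by MTT assay, with a stated time of 24 h, tested at 10 uM; on this read-out lower numbers stand for less inhibition and higher numbers for more inhibition at the one concentration tested (going by the name of the read-out):

Compound 1, `CC(C)=CCC/C(C)=C/COc1cc(=O)n(CCCO)c2c1CC(CC=C(C)C)C(C)(C)C2`, gives 18.4%.
Compound 2, `CC(C)=CCC1Cc2c(OCCCNS(=O)(=O)c3ccc(Cl)cc3)cc(=O)n(CCCO)c2CC1(C)C`, gives 9.8%.
Compound 3, `CC(C)=CCC/C(C)=C/CC1Cc2c(OCCCNS(=O)(=O)c3ccc(Cl)cc3)cc(=O)n(CCCO)c2CC1(C)C`, gives 16.1%.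

Compound 3 holds the second highest of the three numbers, but the spread is small: compound 1 lies only a little higher, and compound 2 a little lower, and both of these gaps fall within the scatter of repeated measurements, so the three compounds cannot be told apart on this read-out.

Compound 4, `CC(C)=CCC/C(C)=C/CC1Cc2c(OCCCNC(=O)c3ccc([N+](=O)[O-])cc3)cc(=O)n(CCCO)c2CC1(C)C`, differs from compound 3 in one place: (4-nitrophenyl)carbonyl in place of (4-chlorophenyl)sulfonyl on an amine nitrogen. Going by the values given here, the only measured step, a number 6.3 percentage points higher from compound 2 to compound 3 (within the scatter), concerns the 3-methylbut-2-en-1-yl group on the ring and leaves the part attached to the amine nitrogen untouched, so it gives no guidance on the present change. Among the compounds with values here, there is no measured step that bears on swapping the (4-chlorophenyl)sulfonyl group for a (4-nitrophenyl)carbonyl group. Because compound 2 gives 9.8% and compound 1 gives 18.4% and every number seen so far sits in the same narrow band between these two, compound 4 is expected to stay in that band as well, with a step of a number 0.1 percentage points lower from compound 3 to compound 4 (within the scatter) that is not expected to exceed the scatter. For compound 4 the estimated value in this assay is 16%, expected to fall between 4% and 30%.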

Compound 4, a percentage reported as inhibition, at one concentration (the size of the read-out at that concentration, not a potency): 6.5%
For compound 4 the middle estimate is 9.5 percentage points above the measured one; the range from low to high includes it.
By their numbers in this assay, from the lowest: compounds 4, 2, 3 and 1 (each within the scatter of the next, the first and the last beyond it).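

In this assay, putting (4-nitrophenyl)carbonyl in place of (4-chlorophenyl)sulfonyl on the amine nitrogen gives a number 9.6 percentage points lower from compound 3 to compound 4 (within the scatter). Going by these compounds alone, this is the first step at this position, which the earlier compounds left untouched, and it shows that this exchange does not separate compound 3 from compound 4 beyond the usual scatter at the one concentration tested. The exchange also alters two things at once, the link to the amine nitrogen and the group on the aromatic ring, and no measured reason for the size of the step is available here.

The compounds shown leave open what each of those two parts contributes alone, which a pairing of the sulfonyl link with 4-nitrophenyl, or of the carbonyl link with 4-chlorophenyl, could begin to separate. They also leave open whether a quite different group on this nitrogen, such as a carboxylic acid or a longer chain ending in an amine, would move the inhibition beyond the scatter, and whether the same exchange would give a similar step on the core of compound 2.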